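Furan-2-yl in place of 4-(trifluoromethyl)phenyl on a carbonyl carbon

The source may report more compounds than this note shows. Statements on the series, on what has been measured and on what is new or still open speak of the compounds shown alone.

Three compounds share one core. Compound 1 `CCOC(=O)c1sc(-c2cccc(NC(=O)c3ccc(C(F)(F)F)cc3)c2)nc1Nc1ccc(N2CCN(C)CC2)cc1` carries an ester on that core and in a functional assay on Ramos cells (Homo sapiens) for antiproliferative activity, read by CCK-8 assay, with a stated time of 72 h (a higher number here means a weaker inhibitor, a lower number a stronger inhibitor), compound 1 gives "not determined" (no result reported), so no number stands for it. Compound 2 `CN1CCN(c2ccc(Nc3nc(-c4cccc(NC(=O)c5ccccc5F)c4)sc3C(=O)O)cc2)CC1` carries a carboxylic acid and gives 6300 nM. Compound 3 `CN1CCN(c2ccc(Nc3nc(-c4cccc(NC(=O)c5ccc(C(F)(F)F)cc5)c4)sc3C(N)=O)cc2)CC1` carries a primary carboxamide and gives 1580 nM, the lower of the two numbers; the gap to compound 2 is beyond the scatter, but the two differ in more than one place, so no single change can be tied to it.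

Compound 4 `CN1CCN(c2ccc(Nc3nc(-c4cccc(NC(=O)c5ccco5)c4)sc3C(N)=O)cc2)CC1` differs from compound 3 in one place: furan-2-yl in place of 4-(trifluoromethyl)phenyl on a carbonyl carbon. Within the data shown here, no measured pair isolates a change of this kind, so there is nothing to calibrate against. A smaller aromatic cap replacing a larger one at this position is expected to cost some activity, though not much beyond the scatter. For compound 4 the expected step of a 1.9-fold higher number from compound 3 to compound 4 (0.28 log units; within the scatter) is therefore a moderate rise. Compound 4 is estimated at 3000 nM, within 1000 nM to 10000 nM.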

Compound 4, half-maximal inhibitory concentration: 19700 nM
Beside the measured number, compound 4's estimate is 6.6-fold (0.82 log units) below it; measured number outside the range, above it.
By their numbers in this assay, from the lowest: compound 3; then compound 2; then compound 4.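

In this assay, among these compounds, the group on the carbonyl carbon whose other neighbour is the amide-type nitrogen carries real weight: with the primary carboxamide held constant, the change gives a 12-fold higher number from compound 3 to compound 4 (1.10 log units; beyond the scatter) and is the first step that can be tied to a single place. Furan-2-yl is therefore no close stand-in for 4-(trifluoromethyl)phenyl here, and the loss lies well beyond the scatter. No measurement shown bears on the origin of this loss.

Still open, from the compounds shown here alone, is which part of the change carries the step: the ring size, the ring oxygen or the trifluoromethyl group. Unsubstituted phenyl or thiophen-2-yl on the same carbonyl, with the primary carboxamide kept, would begin to separate these.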